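Following compound 1 to compound 3

The compounds below may be only part of what the source reports. "The series", "measured", "known", "first", "only" and "open" are said of these compounds alone.

Compound 1 (`CCCC(=O)OCSc1ccccc1C(=O)NCCCC(N)=O`) reads 56.6 uM in an ADME assay on CEM-SS cells (Homo sapiens) for cytotoxicity, read by XTT assay, with a stated time of 6 days; on this read-out lower numbers stand for higher toxicity in this test and higher numbers for lower toxicity in this test
Compound 2 (`CCCC(=O)OCSc1ccccc1C(=O)N[C@H]1CCC[C@@H]1C(N)=O`) reads 31.2 uM; 43.3 uM (2 entries) in this assay

Among the compounds with values here, compound 1 has only one number in this assay, and one further entry for it carries no single number. That number lies within the usual scatter of both readings of compound 2 (the several entries of compound 2 in this assay, 31.2 uM; 43.3 uM (2 entries)), so the two compounds cannot be told apart on these data.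

Compound 3 (`CCCC(=O)OCSc1ccccc1C(=O)N(C)CC(N)=O`) has not yet been measured. It carries (carbamoylmethyl)(methyl)amino in place of (3-carbamoylpropyl)amino on a carbonyl carbon. No measured pair sizes this change, so no shift beyond the scatter is expected in this assay, in either direction. The expected step of a 1.1-fold higher number from compound 1 to compound 3 (0.03 log units; within the scatter) is estimated to stay inside that scatter. The estimate for compound 3 is 60 uM (expected range 25 uM to 130 uM).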

Compound 3, half-maximal toxic concentration: 55.3 uM
Estimate against measurement, compound 3: 1.1-fold (0.04 log units) above; measured number inside the range.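

Placing (carbamoylmethyl)(methyl)amino in place of (3-carbamoylpropyl)amino on the carbonyl carbon gives a 1.0-fold lower number from compound 1 to compound 3 (0.01 log units; within the scatter) in this assay, the first sized step at this position. The entering group carries a methyl where compound 1 has the amide hydrogen, and it also has a shorter chain to the carbamoyl group, yet compound 1 and compound 3 cannot be told apart on this read-out. The step is also small compared with the spread seen between repeat readings of a single compound: the several entries of compound 2 in this assay, 31.2 uM; 43.3 uM (2 entries)

Since the methyl and the shorter chain arrive together in compound 3, the compounds shown do not separate the two changes. They also leave open whether a carboxylic acid or an amine in place of the terminal carbamoyl group would give a step beyond the scatter.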